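The compounds below may be only part of what the source reports. "The series", "measured", "known", "first", "only" and "open" are said of these compounds alone.

Measured in a functional assay on KB cells (Homo sapiens) for antiproliferative activity, read by colorimetric assay and MTT assay; a lower number here means a stronger inhibitor, a higher number a weaker inhibitor:
- compound 1 `O=S(=O)(Nc1cccc2cc[nH]c12)c1ccc(Cl)cc1`: 6 ug/mL
- compound 2 `Cc1ccc(S(=O)(=O)Nc2cccc3cc(Cl)[nH]c23)cc1`: 0.11 ug/mL

Compound 2, at 0.11 ug/mL, holds the lower of the two numbers in this assay and is thus the stronger inhibitor of the pair. Compound 1, at 6 ug/mL, lies above it by a gap beyond the usual scatter.

The next compound is compound 3 `Nc1ccc(S(=O)(=O)Nc2cccc3cc(Cl)[nH]c23)cc1`, which is still to be measured. It has amino in place of methyl on an aromatic carbon, para to a large group, so that 4-methylphenyl becomes 4-aminophenyl (amino in place of methyl on an aromatic carbon). The rest of the structure stays as in compound 2.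

Among the compounds with values here, no measured pair differs in one place only, so the data give no direct guide to the size of this change. A single-atom exchange at this site gives no firm reason to expect a large shift. The step of a 1.6-fold higher number from compound 2 to compound 3 (0.21 log units; within the scatter) is expected to stay within the scatter, with a slight lean towards a higher number.

For compound 3 the estimated value is 0.18 ug/mL, with an expected range from 0.05 ug/mL to 0.7 ug/mL.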

Compound 3, half-maximal inhibitory concentration: 1.4 ug/mL
The estimate for compound 3 lay 7.8-fold (0.89 log units) below the measured number, outside the stated range (above it).
By their numbers in this assay, from the lowest: compound 2; then compound 3; then compound 1.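

Within the data shown here, exchanging 4-methylphenyl for 4-aminophenyl in this assay gives a 13-fold higher number from compound 2 to compound 3 (1.10 log units; beyond the scatter) as the first step that can be read at a single place, and it is a large one. This aromatic carbon, para to a large group, is therefore not indifferent to what it carries: with the rest of the structure unchanged, replacing one carbon atom by one nitrogen atom at this site weakens inhibition well beyond the scatter, and of these two groups methyl gives the stronger inhibitor. The exchange also adds one hydrogen-bond donor and one hydrogen-bond acceptor by count, but nothing at hand bears on what lies behind the step.

From the compounds shown here alone, with only methyl and amino compared at this carbon, it remains open whether methoxy, a carboxylic acid, dimethylamino or a longer chain such as ethyl would stay close to compound 2 or move towards compound 3. Among these compounds, also open is whether the same exchange would give a step of similar size on a core that carries no chlorine, since every step so far rests on this one pair.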